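Two chlorines in place of two fluorines: expected growth inhibition

The source may report more compounds than this note shows. Statements on the series, on what has been measured and on what is new or still open speak of the compounds shown alone.

Compound 1, `CN1CCN(CCCOc2cccc3nc(Nc4ccc(Cl)c(F)c4)ccc23)CC1`, gives 1990 nM in a functional assay on cells (Panel ovarian (Carcinoma cell lines), Homo sapiens) for inhibition, read by sulforhodamine B assay, with a stated time of 48 h; on this read-out lower numbers stand for stronger inhibition of growth and higher numbers for weaker inhibition of growth.
Compound 2, `CN1CCN(CCCOc2cccc3nc(Nc4ccc(F)c(F)c4)ccc23)CC1`, gives 5130 nM in this assay.

Among the compounds with values here, compound 2 gives the higher of the two numbers; the only measured step, a 2.6-fold higher number from compound 1 to compound 2 (0.41 log units; beyond the scatter), is modest. Compound 3, `CN1CCN(CCCOc2cccc3nc(Nc4cc(Cl)cc(Cl)c4)ccc23)CC1`, differs from compound 2 by 3,5-dichlorophenyl in place of 3,4-difluorophenyl on a nitrogen on an aromatic ring. Within the data shown here, that step runs the other way from the one measured: since a 2.6-fold higher number from compound 1 to compound 2 (0.41 log units; beyond the scatter) shows fluoro replacing chloro raising the number, putting chlorines back is expected to lower it, although the positions also shift and no measured pair tests that. Compound 3 is therefore expected to give 1500 nM (range 400 nM to 6000 nM), a step of a 3.4-fold lower number from compound 2 to compound 3 (0.53 log units; beyond the scatter).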

Compound 3, concentration for 50% growth inhibition: 1870 nM
Beside the measured number, compound 3's estimate is 1.2-fold (0.10 log units) below it; the range from low to high includes it.
By their numbers in this assay, from the lowest: compounds 3 and 1 (each within the scatter of the next); then compound 2.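

Swapping 3,4-difluorophenyl for 3,5-dichlorophenyl on this nitrogen gives a clear change in this assay (a 2.7-fold lower number from compound 2 to compound 3 (0.44 log units; beyond the scatter)), so the two chlorines here do better than the two fluorines. Against the chloro-fluoro compound there is no real separation (a 1.1-fold lower number from compound 1 to compound 3 (0.03 log units; within the scatter)), so 3,5-dichlorophenyl and 4-chloro-3-fluorophenyl cannot be told apart at this position. Nothing available explains these results. As far as these compounds go, what a plain phenyl, or a phenyl bearing methoxy or trifluoromethyl, would give on this nitrogen stays open.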